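Adding a Fluorine to the Benzyl Group of Compound 3

The source may report more compounds than this note shows. Statements on the series, on what has been measured and on what is new or still open speak of the compounds shown alone.

Among the compounds with values here, in an assay on isolated protein for inhibition of protein deacetylase HDAC6 (Homo sapiens), read by mobility shift assay (on this read-out lower numbers stand for stronger inhibition and higher numbers for weaker inhibition), compound 3 `O=C(NO)c1ccc(CN(Cc2ccccc2)S(=O)(=O)c2cc(F)c(F)c(F)c2F)cc1` gives 5 nM, the lowest of the three numbers measured so far. Compound 2 `O=C(NO)c1ccc(CN(Cc2ccncc2)S(=O)(=O)c2cc(F)c(F)c(F)c2F)cc1` gives 11 nM and compound 1 `O=C(NO)c1ccc(CN(Cc2ccc(F)cc2)S(=O)(=O)c2c(F)c(F)c(F)c(F)c2F)cc1` gives 13 nM. Within the data shown here, the only single-change step measured, a 2.2-fold lower number from compound 2 to compound 3 (0.34 log units; beyond the scatter), concerns a different part of the molecule. Compound 4 `O=C(NO)c1ccc(CN(Cc2ccc(F)cc2)S(=O)(=O)c2cc(F)c(F)c(F)c2F)cc1` differs from compound 3 by fluoro in place of hydrogen on an aromatic carbon, on an aromatic carbon of a six-membered aromatic ring of carbon only, para to a large group. Among the measured compounds shown here, no measured step tests this change directly; compound 1 also carries a fluoro on that ring, but it differs from compound 3 in more than one place. A small step is therefore expected, a 1.4-fold higher number from compound 3 to compound 4 (0.15 log units; within the scatter), likely within the scatter. Compound 4 is estimated at 7 nM, in a range from 3 nM to 16 nM.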

Compound 4, half-maximal inhibitory concentration: 21 nM
Beside the measured number, compound 4's estimate is 3.0-fold (0.48 log units) below it, outside the stated range (above it).
By their numbers in this assay, from the lowest: compound 3; then compounds 2, 1 and 4 (each within the scatter of the next).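

In this assay, a single fluoro at this spot on the benzyl ring matters: the change gives a 4.2-fold higher number from compound 3 to compound 4 (0.62 log units; beyond the scatter). The other two steps to the new compound stay small: 4-fluorophenyl in place of pyridin-4-yl gives a 1.9-fold higher number from compound 2 to compound 4 (0.28 log units; within the scatter), and hydrogen in place of fluoro on the other aromatic ring gives a 1.6-fold higher number from compound 1 to compound 4 (0.21 log units; within the scatter). Nothing available explains the effect of the fluoro.

Going by these compounds, whether a chloro, methyl or methoxy group at this same place would act like fluoro remains open. So does whether the step depends on the rest of the molecule.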